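This account rests on a few compounds, and the source may have more. Where it says the series, first, only, none or still open, it means among the compounds named here.

Three compounds share one core and differ only in the saturated ring at the end of the side chain and in the group on the outer aromatic ring. Compound 1 `COc1cc2c(Oc3ccc(NC(=O)N/N=C/c4ccc([N+](=O)[O-])cc4)cc3F)ccnc2cc1OCCCN1CCCC1` carries a nitro group there, and in a functional assay on MDA-MB-231 cells (Homo sapiens) for cytotoxicity, read by MTT assay, with a stated time of 72 h (on this read-out higher numbers stand for weaker inhibition and lower numbers for stronger inhibition), compound 1 gives 970 nM. Compound 2 `COc1ccc(/C=N/NC(=O)Nc2ccc(Oc3ccnc4cc(OCCCN5CCCCC5)c(OC)cc34)c(F)c2)cc1` carries a methoxy group and a different saturated ring; in this assay compound 2 gives 840 nM. Compound 3 `COc1ccc(/C=N/NC(=O)Nc2ccc(Oc3ccnc4cc(OCCCN5CCC(C)CC5)c(OC)cc34)c(F)c2)cc1` adds a methyl to that saturated ring; in this assay compound 3 gives 1000 nM. Going by the values given here, the single direct comparison, a 1.2-fold higher number from compound 2 to compound 3 (0.08 log units; within the scatter), shows the methyl makes no difference that can be told from noise. Compound 3 thus stands among its neighbours: its distances from compound 1 and from compound 2 both lie within the scatter.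

Compound 4 `COc1cc2c(Oc3ccc(NC(=O)N/N=C/c4ccc([N+](=O)[O-])cc4)cc3F)ccnc2cc1OCCCN1CCC(C)CC1` keeps the methylated saturated ring of compound 3 and makes the change (nitro in place of methoxy on an aromatic carbon). Among the compounds with values here, no measured pair isolates this swap: compound 1 and compound 2 differ both in the saturated ring and in this group, and their values sit within the scatter of each other, which hints that exchanging methoxy for nitro leaves the read-out roughly where it was. The step of no change at the digits printed from compound 3 to compound 4 (within the scatter) is therefore expected to be small or absent. Compound 4 is estimated at 1000 nM, with a likely range from 500 nM to 2000 nM.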

Compound 4, half-maximal inhibitory concentration: 870 nM
For compound 4 the middle estimate is 1.1-fold (0.06 log units) above the measured one, within the range that was stated.
By their numbers in this assay, from the lowest: compounds 2, 4, 1 and 3 (each within the scatter of the next).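

The swap of methoxy for nitro on this aromatic carbon, para to a large group, can now be read directly with the methylated saturated ring held fixed: this assay shows a 1.1-fold lower number from compound 3 to compound 4 (0.06 log units; within the scatter) and so gives no sign that this exchange at this position moves the read-out. Compound 4 also supplies a second clean pair with the nitro group held fixed, with 4-methylpiperidin-1-yl in place of pyrrolidin-1-yl on the side chain, and that change gives a 1.1-fold lower number from compound 1 to compound 4 (0.05 log units; within the scatter) in the same assay, so all three single-place steps among these four compounds lie within the scatter and none goes against that picture. No measurement is at hand that would explain why these steps are so small.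

On these data alone, it remains open whether a different group on the outer aromatic ring, such as an amine or a carboxylic acid, would give a number that can be told apart from those of methoxy and nitro. As far as these compounds go, it is equally open whether a morpholine ring at the end of the side chain, or a longer chain leading to it, would do so.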